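A few compounds are considered here, and "the series" means these few. Any claim that something is new, unique, unknown or untested is made for them only; others in the source may bear on it.

Compound 1 (`CCCCn1c(-c2ccccc2)c(C)[nH]c1=O`) gives > 100000 nM in a functional assay on brain (Rattus norvegicus, strain Wistar) for inhibition (a higher number here means a weaker inhibitor, a lower number a stronger inhibitor), which is a limit of the assay and not a number. Among the compounds with values here, compound 2 (`Cc1[nH]c(=O)n(C2CCCCC2)c1-c1ccccc1`) reads 47600 nM, the only actual number so far, and it remains a weak inhibitor on that scale. Within the data shown here, the one measured step, an at least 2.1-fold lower number from compound 1 to compound 2 (0.32 log units; beyond the scatter), puts cyclohexyl in place of butyl on an aromatic nitrogen, and its size rests on (the limit of > 100000 nM in this assay, at which 1 of the 2 values shown sits).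

Compound 3 (`COc1ccc(-c2c(C)[nH]c(=O)n2C2CCCCC2)cc1`) keeps the cyclohexyl of compound 2 and has methoxy in place of hydrogen on an aromatic carbon, para to a large group (methoxy in place of hydrogen on an aromatic carbon). Among the measured compounds shown here, the measured step lies at a different place, so it gives no direct guide to this change, and no measured step covers it. No shift beyond the scatter is therefore expected in this assay, and the estimated 1.6-fold lower number from compound 2 to compound 3 (0.20 log units; within the scatter) is small. For compound 3 the expected value is 30000 nM, with an estimated range of 8000 nM to 100000 nM.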

Compound 3, half-maximal inhibitory concentration: 20400 nM
Estimate against measurement, compound 3: 1.5-fold (0.17 log units) above; low and high end bracket the measured number.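

The aromatic ring carrying the new group, unchanged between compound 1 and compound 2, now gives its first reading: methoxy in place of hydrogen on an aromatic carbon, para to a large group, gives a 2.3-fold lower number from compound 2 to compound 3 (0.37 log units; beyond the scatter) in this assay. Both ends of this step are actual numbers, so its size is fixed and does not rest on a limit. Compound 3 at 20400 nM remains a weak inhibitor on this scale. Nothing available here accounts for the shift.

It remains open whether this step is particular to methoxy, since a hydroxyl, a fluorine or a dimethylamino group at the same place has no reading among these compounds. Also open, from the compounds shown here alone, is whether the same step would appear with butyl rather than cyclohexyl on the aromatic nitrogen.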